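This account rests on a few compounds, and the source may have more. Where it says the series, first, only, none or still open, it means among the compounds named here.

Compound 2 `COc1ccc2c(=O)c(/C=C/C(=O)NCc3ccccc3F)coc2c1` gives 146000 nM in an ADME assay on HepG2 2.2.15 cells (Homo sapiens) for cytotoxicity, read by MTT assay, with stated times of 48 h and 9 days; a lower number here means that less compound is tolerated, a higher number that more compound is tolerated. Among the three measured compounds it stands second highest: compound 1 `COc1ccc2c(=O)c(/C=C/C(=O)NCc3ccc(F)cc3)coc2c1` gives 133000 nM, while compound 3 `COc1ccc(NC(=O)/C=C/c2coc3cc(O)ccc3c2=O)cc1` gives 976000 nM, a gap from compound 2 that lies beyond the scatter. Going by the values given here, the only measured step touching the ring on the amide-type nitrogen, a 1.1-fold higher number from compound 1 to compound 2 (0.04 log units; within the scatter), stayed within the scatter. Compound 4 `COc1ccc2c(=O)c(/C=C/C(=O)Nc3ccccc3C)coc2c1` differs by 2-methylphenyl in place of 2-fluorobenzyl on an amide-type nitrogen. Among the compounds with values here, no measured pair isolates this change on its own, and compound 3 differs from compound 2 in more than one place, so its higher number is only weak guidance. The step from compound 2 to compound 4 is expected to be a modest rise, a 1.7-fold higher number from compound 2 to compound 4 (0.23 log units; within the scatter). Compound 4 is therefore estimated at 250000 nM, with a range from 100000 nM to 700000 nM.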

Compound 4, half-maximal cytotoxic concentration: 59700 nM
The estimate for compound 4 lay 4.2-fold (0.62 log units) above the measured number, and the stated range ends above it.
By their numbers in this assay, from the lowest: compound 4; then compounds 1 and 2 (each within the scatter of the next); then compound 3.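

On an amide-type nitrogen, 2-methylphenyl in place of 2-fluorobenzyl gives a 2.4-fold lower number from compound 2 to compound 4 (0.39 log units; beyond the scatter) in this assay and, in place of 4-fluorobenzyl, gives a 2.2-fold lower number from compound 1 to compound 4 (0.35 log units; beyond the scatter). Moving the fluorine had stayed within the scatter, so this position does respond, but to replacing the whole group. Nothing shown here explains the lower number. The compounds leave open whether it goes with the lost chain carbon or with methyl replacing fluorine: neither a 2-methylbenzyl group nor a 2-fluorophenyl group bound straight to this nitrogen stands among them.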